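Methyl on the terminal phenyl: outlook for compound 3

The source may hold more compounds than are shown below. What is called first, only, known or untested is meant among the compounds shown, and "the series" means these compounds.

Compound 1 `CN(C)CCNc1nc(-c2ccc(NC(=O)Nc3ccccc3)cc2)nc2ccsc12`: 1310 nM
Compound 2 `CCN(CC)CCCNc1nc(-c2ccc(NC(=O)Nc3ccccc3)cc2)nc2ccsc12`: 1230 nM

In a functional assay on MDA-MB-231 cells (Homo sapiens) for cytotoxicity, read by MTT assay, with a stated time of 72 h (a lower number here means a stronger inhibitor, a higher number a weaker inhibitor), compound 2 stands nearest to compound 1, the two numbers lying within the scatter of each other, so no order between them is claimed. Among the measured compounds shown here, the only measured step, a 1.1-fold lower number from compound 1 to compound 2 (0.03 log units; within the scatter), changed the group on the saturated chain and left the aromatic rings untouched. Compound 3 `CCN(CC)CCCNc1nc(-c2ccc(NC(=O)Nc3ccc(C)cc3)cc2)nc2ccsc12` differs from compound 2 by methyl in place of hydrogen on an aromatic carbon. For the measured compounds named here, no measured step bears on this ring position; in this assay a step no larger than the scatter is therefore expected, namely a 1.0-fold lower number from compound 2 to compound 3 (0.01 log units; within the scatter). Compound 3 is estimated at 1200 nM, range 600 nM to 2400 nM.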

Compound 3, half-maximal inhibitory concentration: 1980 nM
Compound 3: middle estimate off by 1.7-fold (0.22 log units), on the low side; low and high end bracket the measured number.
By their numbers in this assay, from the lowest: compounds 2, 1 and 3 (each within the scatter of the next).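

The terminal phenyl ring now has a measured step: in this assay, phenyl to 4-methylphenyl gives a 1.6-fold higher number from compound 2 to compound 3 (0.21 log units; within the scatter). This step stays within the scatter, so methyl at this aromatic carbon, para to a large group, is not separated from hydrogen in this assay. No separate measurement bears on this step.

Still open, on these data alone, is whether a methoxy group, chlorine, an amine or a carboxylic acid at this carbon would give a step beyond the scatter. Also open, as far as these compounds go, is whether methyl on another carbon of this ring would do so.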